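Ring-nitrogen substituents in a positive allosteric modulator series

The source may hold more compounds than are shown below. What is called first, only, known or untested is meant among the compounds shown, and "the series" means these compounds.

In a functional assay on the whole organism for positive allosteric modulation, with Rattus norvegicus as the target (a higher number here means that more compound is needed for the effect, a lower number that less compound is needed), the measured compounds give:
compound 1, `Cc1nn(C)c2c1C(c1cccc(Cl)c1)=NCCN2C`: 0.63 mg/kg
compound 2, `CC(=O)N1CCN=C(c2cccc(Cl)c2)c2c(C)nn(C)c21`: > 10 mg/kg, which is a limit of this assay and not a number
compound 3, `Cc1nn(C)c2c1C(c1cccc(Cl)c1)=NCCN2N=O`: 1.25 mg/kg

Compound 3 holds the highest of the two numbers, but the step of a 2.0-fold higher number from compound 1 to compound 3 (0.30 log units; within the scatter) lies within the scatter, so compound 1 and compound 3 are not separated. Among the measured compounds shown here, the only other value is the limit noted for compound 2 (the limit of > 10 mg/kg in this assay, at which 1 of the 3 values shown sits).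

Compound 4 is `Cc1nn(C)c2c1C(c1cccc(Cl)c1)=NCCN2CCCN(C)C`. It differs from compound 3 as follows:
a group of 6 heavy atoms (5 carbon, 1 nitrogen; no ring) in place of a group of 2 heavy atoms (1 nitrogen, 1 oxygen; no ring), on a nitrogen on an aromatic ring in a ring

For the measured compounds named here, two measured steps bear on this position. The step of an at least 15-fold higher number from compound 1 to compound 2 (1.20 log units; beyond the scatter) shows that an acetyl on the ring nitrogen is poorly tolerated; the step of an at least 8.0-fold lower number from compound 2 to compound 3 (0.90 log units; beyond the scatter) returns most of that loss when a smaller group sits there. The entering 3-(dimethylamino)propyl is larger than any group measured at this nitrogen, so the measured steps do not cover it directly. A modest rise in this assay, with a wide range and a real chance of a limit, is therefore expected.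

Compound 4 is expected to give 2.5 mg/kg, with a range from 0.6 mg/kg to 10 mg/kg. The expected step is a 2.0-fold higher number from compound 3 to compound 4 (0.30 log units; within the scatter).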

Compound 4, minimum effective dose: > 10 mg/kg
Compound 4: a limit, no number; the forecaster's own chance of this, stated with the estimate: 30%; middle value at least 4.0-fold (0.60 log units) from the limit.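

At this nitrogen, the loss in this assay is no longer confined to acetyl, since the 3-(dimethylamino)propyl of compound 4 also removes the effect seen with the smaller groups. The change reads as an at least 8.0-fold higher number from compound 3 to compound 4 (0.90 log units; beyond the scatter) and as an at least 15-fold higher number from compound 1 to compound 4 (1.20 log units; beyond the scatter). Compound 4 gives a limit of the assay and not a number, and it shares that limit with compound 2, so the step between them cannot be read: the limit of > 10 mg/kg in this assay, at which 2 of the 4 values shown sit.

Acetyl and 3-(dimethylamino)propyl therefore cannot be ranked against each other at this nitrogen. On these data alone, whether the loss with compound 4 follows the length of the chain or its terminal dimethylamino group stays open, and a plain propyl chain or a shorter dimethylaminoethyl chain at this nitrogen would bear on that.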